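Chromone thioethers with azole heads: cytotoxicity notes

A few compounds are considered here, and "the series" means these few. Any claim that something is new, unique, unknown or untested is made for them only; others in the source may bear on it.

- Compound 1 `Cc1nnc(SCc2cc(=O)c3cc(Cl)ccc3o2)o1`: in a functional assay on LM7 cells (Homo sapiens) for cytotoxicity, read by MTT assay, with a stated time of 72 h (on this read-out lower numbers stand for stronger inhibition and higher numbers for weaker inhibition), compound 1 gives > 25000 nM, which is a limit of the assay and not a number.
- Compound 2 `Cc1ccc2oc(CSc3nnc(C)s3)cc(=O)c2c1`: in this assay compound 2 gives > 25000 nM, again a limit rather than a number.
- Compound 3 `Cc1ccc2oc(CSc3nnc(N)s3)cc(=O)c2c1`: in this assay compound 3 gives > 25000 nM, also a limit.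

Compound 3 thus stands at the limit, as do the other two measured compounds; all three values sit where the limit of > 25000 nM in this assay, at which 3 of the 3 values shown sit, describes. Within the data shown here, the only single-point step among them, a step that the two limits leave unreadable from compound 2 to compound 3, is unreadable for that reason.

Compound 4 `Cc1ccc2oc(CSc3nnc(C)o3)cc(=O)c2c1` differs from compound 3 by 5-methyl-1,3,4-oxadiazol-2-yl in place of 5-amino-1,3,4-thiadiazol-2-yl on a sulfur. Compound 1 already carries the 5-methyl-1,3,4-oxadiazol-2-yl head on a differently substituted core and gives a limit, and compound 2 shows that the methyl-bearing azole on the shared core of compound 3 also gives a limit. Among the measured compounds shown here, no measured step bears on this change in a readable way, so no step beyond the scatter is expected in this assay in either direction; the estimated step that the limit leaves unreadable from compound 3 to compound 4 is set near zero. Compound 4 is therefore expected to give about 40000 nM, within 20000 nM to 100000 nM, and most likely to be reported only as a limit.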

Compound 4, half-maximal inhibitory concentration: > 25000 nM
Compound 4: a limit, no number (the forecaster's own chance of this, stated with the estimate: 85%); the middle value lies beyond the limit too.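

The result for compound 4 is a limit and not a number, so no step to it from compound 1, compound 2 or compound 3 can be read: the limit of > 25000 nM in this assay, at which 4 of the 4 values shown sit.

The compounds shown leave open whether changing the azole head or the core substituent alters cytotoxicity at all.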